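This account rests on a few compounds, and the source may have more. Where it says the series, first, only, none or still open, it means among the compounds named here.

Compounds measured in an assay on a protein complex for inhibition of ubiquitin carboxyl-terminal hydrolase 1/WD repeat-containing protein 48 (Homo sapiens), read by fluorescence; on this read-out lower numbers stand for stronger inhibition and higher numbers for weaker inhibition:
- compound 1, `O=[N+]([O-])c1ccccc1-c1nc(NCc2ccc(-c3cccnc3)cc2)c2ccccc2n1`: 7800 nM
- compound 2, `FC(F)c1ccccc1-c1nc(NCc2ccc(-c3cccnc3)cc2)c2ccccc2n1`: 1400 nM
- compound 3, `c1cncc(-c2ccc(CNc3nc(C4CCCC4)nc4ccccc34)cc2)c1`: "not active" (no number reported)

Compound 3 therefore stands apart from compounds 1 and 2: for compound 3 there is no value at all in this assay, only the report that it showed no activity, whereas compound 1 and compound 2 each give a measurable number.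

Compound 4, `c1cncc(-c2ccc(CNc3nc(-n4ccnc4)nc4ccccc34)cc2)c1`, differs from compound 3 in one place: 1H-imidazol-1-yl in place of cyclopentyl on an aromatic carbon. Among the compounds with values here, the only measured step, a 5.6-fold lower number from compound 1 to compound 2 (0.75 log units; beyond the scatter), concerns a change on a different part of the shared core and so says nothing direct about an exchange of cyclopentyl for 1H-imidazol-1-yl. What the data do show is that the two compounds carrying an aromatic ring at this position, compound 1 and compound 2, both give numbers, while compound 3, which carries the cyclopentyl, gives none. Compound 4 brings back an aromatic ring at that place; whereas compound 3 is reported as "not active" (no number reported), compound 4 is expected to move toward a measurable but weak number, though it may still fall outside the assay's reach. Compound 4 is estimated at 6000 nM, with a range from 1000 nM to 40000 nM.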

Compound 4, half-maximal inhibitory concentration: "not active" (no number reported)
Nothing numeric was reported for compound 4; there is nothing to compare the estimate with.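

In this assay compound 4 gives "not active" (no number reported) and compound 3 gives "not active" (no number reported), so no step can be read between them. No available evidence bears on this result. The compounds shown leave open whether 1H-imidazol-1-yl in place of cyclopentyl changes inhibition at all, and how far compound 3 and compound 4 lie from a measurable number.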